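Amide side chain change from compound 2 to compound 4

A few compounds are considered here, and "the series" means these few. Any claim that something is new, unique, unknown or untested is made for them only; others in the source may bear on it.

Compound 1 `COc1ccc(OC(F)(F)F)cc1Cn1c(C(=O)NCC(C)(C)CO)cc2cc(C#N)ccc21` gives 31 mL.min-1.g-1 in an in vitro ADME assay on microsomes from liver (Homo sapiens) for metabolic stability, in the presence of a further agent that is not named here; on this read-out lower numbers stand for slow clearance and higher numbers for fast clearance
Compound 2 `COc1ccc(Br)cc1Cn1c(C(=O)NCC(C)(C)CO)cc2cc(C#N)ccc21` gives 23 mL.min-1.g-1 in this assay
Compound 3 `Cc1ccc(Cl)cc1Cn1c(C(=O)NCC(C)(C)CO)cc2cc(C#N)ccc21` gives 23 mL.min-1.g-1 in this assay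

Compound 2 shares its number with compound 3, and all three values lie within the scatter of one another. For the measured compounds named here, two measured steps bear on the series: a 1.3-fold lower number from compound 1 to compound 2 (0.13 log units; within the scatter) for bromo in place of trifluoromethoxy, and no change at the digits printed from compound 2 to compound 3 (within the scatter) for 5-chloro-2-methylphenyl in place of 5-bromo-2-methoxyphenyl.

Compound 4 `COc1ccc(Br)cc1Cn1c(C(=O)NCCCO)cc2cc(C#N)ccc21` keeps the shared core of compound 2 and alters only the amide side chain. The difference is 2-hydroxyethyl in place of 1-(hydroxymethyl)-1-methylethyl on a saturated chain carbon bound to an amide-type nitrogen and, cut one bond further out, it reads 3-hydroxypropyl in place of 2-(hydroxymethyl)-2-methylpropyl.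

Neither measured step touches this place, so the data hold no direct measure of the change, and the two steps serve only as a weak guide. With compound 2 at 23 mL.min-1.g-1 as the anchor, no step beyond the scatter is expected in this assay and no direction can be favoured. The estimated step is a 1.0-fold lower number from compound 2 to compound 4 (0.02 log units; within the scatter) and the range is kept wide. The estimated value for compound 4 is 22 mL.min-1.g-1 with an expected range from 11 mL.min-1.g-1 to 42 mL.min-1.g-1 in this read-out.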

Compound 4, intrinsic clearance in microsomes: < 6 mL.min-1.g-1
Compound 4: no number, only a limit (the forecaster's own chance of this, stated with the estimate: 5%); middle value at least 3.6-fold (0.56 log units) from the limit.
By their numbers in this assay, from the lowest: compounds 2, 3 and 1 (each within the scatter of the next). At a limit, below all of these: compound 4.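

For the compounds shown here, the amide side chain is the first place where this assay shows a step beyond the scatter: 3-hydroxypropyl in place of 2-(hydroxymethyl)-2-methylpropyl gives an at least 3.8-fold lower number from compound 2 to compound 4 (0.58 log units; beyond the scatter), whereas the earlier changes, bromo in place of trifluoromethoxy and 5-chloro-2-methylphenyl in place of 5-bromo-2-methoxyphenyl, both stayed within the scatter. The groups exchanged here match in hydrogen-bond donors and acceptors and differ in heavy atoms, 5 against 3, so the read-out responds to a change that leaves those counts untouched. Compound 4 carries a limit and not a number, so the size of the step has only a bound and its full extent stays unknown: the limit of < 6 mL.min-1.g-1 in this assay, at which 1 of the 4 values shown sits.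

Open, as far as these compounds go, is whether the same side chain change carries over to the aryl groups of compound 1 and compound 3, as the step rests on a single pair. Also open, from the compounds shown here alone, is how a chain bearing one methyl group, a longer chain, or an amine or a carboxylic acid in place of the hydroxy group would read in this assay.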